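Swapping Cyano for Bromo: Estimating a Cell Toxicity Reading

A few compounds are considered here, and "the series" means these few. Any claim that something is new, unique, unknown or untested is made for them only; others in the source may bear on it.

Of the compounds shown here, two have been tested so far in an ADME assay on MDCK cells (Canis lupus familiaris) for cytotoxicity, read by MTT assay, with a stated time of 24 h (on this read-out higher numbers stand for lower toxicity in this test and lower numbers for higher toxicity in this test), and they give the only numbers available here. Compound 1 (`Cc1cc(CNS(=O)(=O)c2ccc(F)cc2)c(C)o1`) reads 138000 nM in this test. Compound 2 (`Cc1cc(CNS(=O)(=O)c2ccc(C#N)cc2)c(C)s1`) reads > 217000 nM in this assay and this figure is a limit of the assay, not a number. Compound 2 therefore has no exact position on the scale.

The next compound to consider is compound 3 (`Cc1cc(CNS(=O)(=O)c2ccc(Br)cc2)c(C)s1`). It keeps the core of compound 2 and carries bromo in place of cyano on an aromatic carbon, para to a large group (bromo in place of cyano on an aromatic carbon). Among the measured compounds shown here, no measured pair shows what this swap does. For the measured compounds named here, the only exact reading to lean on comes from compound 1 at 138000 nM and so a modest move toward lower numbers is expected, no larger than the usual scatter of such measurements. an at least 1.4-fold lower number from compound 2 to compound 3 (0.16 log units; that floor lies within the scatter) is the step expected in this assay for now. Compound 3 is estimated at 150000 nM as the middle value, with an expected range (60000 nM to 300000 nM).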

Compound 3, half-maximal cytotoxic concentration: 56400 nM
For compound 3 the middle estimate is 2.7-fold (0.42 log units) above the measured one; the measured number lies below the stated range.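

Bromo in place of cyano on an aromatic carbon, para to a large group, gives an at least 3.8-fold lower number from compound 2 to compound 3 (0.58 log units; beyond the scatter) in this assay. Among the compounds shown here, this is the first readable sign that the group at this position can shift the reading, as the rest of the structure stays the same and the step lies beyond the usual scatter. The true step could be larger than this floor, because compound 2 has only a limit and not an exact number: the limit of > 217000 nM in this assay, at which 1 of the 3 values shown sits.

Only cyano and bromo are compared at this position on this core, so one step cannot show whether the change tracks the arrival of bromo or the loss of cyano, or where an amine, a methoxy group or a carboxylic acid would fall on the same scale. Compound 1 differs from compound 3 in more than one place, so it cannot settle how fluoro at this position would read on the core of compound 3.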